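The source may report more compounds than this note shows. Statements on the series, on what has been measured and on what is new or still open speak of the compounds shown alone.

Of the compounds shown here, three have been measured in an ADME assay on MRC5 cells (Homo sapiens) for inhibition, with a stated time of 72 h; a lower number here means that less compound is needed, a higher number that more compound is needed for the effect. Compound 1 `CO[C@H]1CC[C@H](NC(=O)c2n[nH]cc2NC(=O)c2cc3ccccn3n2)CC1` gives 1000 nM in this assay. Compound 3 `CO[C@H]1CC[C@H](NC(=O)c2n[nH]cc2NC(=O)c2cc3ccccc3o2)CC1` gives 800 nM in this assay. The step of a 1.3-fold lower number from compound 1 to compound 3 (0.10 log units; within the scatter) concerns the group on the carbonyl carbon and changes nothing on the chain side of the core. Compound 2 `COCCNC(=O)c1n[nH]cc1NC(=O)c1c(OC)cccc1OC` reaches only the limit of this assay, > 50000 nM, so no number is known for it; it stands at the limit of > 50000 nM in this assay, at which 1 of the 3 values shown sits, apart from the two compounds with a value.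

Compound 4 `COc1cccc(OC)c1C(=O)Nc1c[nH]nc1C(=O)NCCCN(C)C` differs from compound 2 in one place: (dimethylamino)methyl in place of methoxy on a saturated chain carbon, two bonds along the chain from an amide-type nitrogen. Within the data shown here, no measured step touches this position; the only step with a number, from compound 1 to compound 3, lies on the other side of the core and gives no guidance here. What is known is that compound 2 itself sits at the limit. The account therefore expects no step beyond the scatter for compound 4 in this assay, and an estimated step of a number no higher from compound 2 to compound 4 (the limit leaves the size open) with a fair chance that the assay again reports only a limit. Compound 4 is estimated to give 50000 nM in this assay, within a range from 12000 nM to 200000 nM.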

Compound 4, half-maximal effective concentration: > 50000 nM
Compound 4: a limit, no number (the forecaster's own chance of this, stated with the estimate: 60%); the middle value lies on the limit itself.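

Compound 2 and compound 4 both give only a limit in this assay, so the step between them cannot be read: the limit of > 50000 nM in this assay, at which 2 of the 4 values shown sit.

The compounds shown leave open what number either compound would give, and whether (dimethylamino)methyl in place of methoxy on this saturated chain carbon changes the result at all.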